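The source may hold more compounds than are shown below. What is called first, only, known or untested is meant among the compounds shown, and "the series" means these compounds.

Among the compounds with values here, in a functional assay on A-431 cells (Homo sapiens) for antiproliferative activity, read by sulforhodamine B assay, with a stated time of 72 h (a lower number here means a stronger inhibitor, a higher number a weaker inhibitor), compound 1 (`C=C1CC(CBr)(c2ccccc2)OC1=O`) gives 1480 nM and holds the lowest of the three numbers so far. Compound 2 (`C=C1CC(CBr)(c2ccccc2C)OC1=O`) gives 5500 nM there, and compound 3 (`C=C1CC(CBr)(c2cccc(C)c2)OC1=O`) gives 4500 nM there. Within the data shown here, compound 4 (`C=C1CC(CBr)(c2ccc(F)cc2)OC1=O`) carries fluoro in place of hydrogen on an aromatic carbon and has no measurement yet. Among the measured compounds shown here, two measured steps bear on it, each a methyl in place of hydrogen on an aromatic carbon: the data show a 3.7-fold higher number from compound 1 to compound 2 (0.57 log units; beyond the scatter) and also a 3.0-fold higher number from compound 1 to compound 3 (0.48 log units; beyond the scatter) for the other methyl compound. Both are modest, yet neither involves fluoro, so they guide only loosely. A small upward step is therefore expected, estimated as a 1.4-fold higher number from compound 1 to compound 4 (0.13 log units; within the scatter) and possibly lost in the scatter. In this assay compound 4 is expected at 2000 nM with an estimated range of 800 nM to 5000 nM around it.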

Compound 4, half-maximal inhibitory concentration: 800 nM
The estimate for compound 4 lay 2.5-fold (0.40 log units) above the measured number, and the stated range covers the measured number.
By their numbers in this assay, from the lowest: compounds 4 and 1 (each within the scatter of the next); then compounds 3 and 2 (each within the scatter of the next).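

With fluoro in place of hydrogen on an aromatic carbon, para to a group of 9 heavy atoms, a 1.9-fold lower number from compound 1 to compound 4 (0.27 log units; within the scatter) in this assay. Within the data shown here, this is the first change to the ring whose step stays within the scatter, whereas the methyl steps show a 3.7-fold higher number from compound 1 to compound 2 (0.57 log units; beyond the scatter) and a 3.0-fold higher number from compound 1 to compound 3 (0.48 log units; beyond the scatter). Nothing available explains this difference between the steps. Still open, on these data alone, is whether this outcome belongs to fluoro or to this place on the ring. A methyl, chloro or methoxy group on the same carbon would help separate the two.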